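This account rests on a few compounds, and the source may have more. Where it says the series, first, only, none or still open, it means among the compounds named here.

Working notes on the series. In a functional assay on A549 cells (Homo sapiens) for antiproliferative activity, read by MTT assay, with a stated time of 48 h (a higher number here means a weaker inhibitor, a lower number a stronger inhibitor), compound 1 (`COc1ccc(/C=C/c2cc(OC)cc(OC)c2/C=C/C(=O)c2cccc(Br)c2)cc1`) gives 8.1 ug/mL and compound 2 (`COc1ccc(/C=C/c2cc(OC)cc(OC)c2/C=C/C(=O)c2ccc(N)cc2)cc1`) gives 3.8 ug/mL, so compound 2 holds the lower of the two numbers. The next compound to read is compound 3 (`CCOc1ccc(C(=O)/C=C/c2c(/C=C/c3ccc(OC)cc3)cc(OC)cc2OC)cc1`), which differs from compound 2 by ethoxy in place of amino on an aromatic carbon, para to a large group. The 4-aminophenyl becomes 4-ethoxyphenyl, and the rest of the structure stays the same.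

Among the measured compounds shown here, only one measured step bears on this change: a 2.1-fold lower number from compound 1 to compound 2 (0.33 log units; beyond the scatter). It is modest, lies beyond the scatter and involves the same aryl group on the carbonyl. For the measured compounds named here, no measured compound carries ethoxy, so this step offers only a rough guide to size. Going by the values given here, compound 3 gives up the amino group of compound 2, and the only measured compound without it, compound 1, stands at 8.1 ug/mL. A modest move towards a higher number in this assay is therefore expected, and the expected step is a 1.6-fold higher number from compound 2 to compound 3 (0.20 log units; within the scatter). Compound 3 is estimated at 6 ug/mL, with an expected range of 2.5 ug/mL to 14 ug/mL.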

Compound 3, half-maximal inhibitory concentration: 7.5 ug/mL
Compound 3: middle estimate off by 1.3-fold (0.10 log units), on the low side, within the range that was stated.
By their numbers in this assay, from the lowest: compounds 2, 3 and 1 (each within the scatter of the next, the first and the last beyond it).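

In this assay, the first change made at this para position gives a 2.0-fold higher number from compound 2 to compound 3 (0.30 log units; within the scatter), so replacing amino with ethoxy, which also removes the hydrogen-bond donor, does not produce a separation that can be relied on. Among the compounds shown here, the comparison with the earlier bromo compound gives a 1.1-fold lower number from compound 1 to compound 3 (0.03 log units; within the scatter), so the 4-ethoxyphenyl and 3-bromophenyl groups on the carbonyl cannot be told apart here, and only the pair of compound 1 and compound 2 stands beyond the scatter. Nothing measured on the series accounts for these numbers.

The three compounds therefore do not settle whether the amino group has a real advantage over ethoxy, or whether a hydroxyl, a methoxy or a longer alkoxy chain in the same place would read with compound 2 or with compound 3. On these data alone, it also remains open whether a dimethylamino group or an acetamide would keep the separation from compound 1, and whether a 4-bromophenyl group would read with the 3-bromophenyl group of compound 1.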